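Rat plasma half-lives of the diester series

The source may report more compounds than this note shows. Statements on the series, on what has been measured and on what is new or still open speak of the compounds shown alone.

Measured compounds and their half-lives:
- compound 1, `CCCCC(=O)O[C@@H]1CO[C@H]2[C@@H]1OC[C@@H]2OC(=O)c1ccccc1OC(C)=O`: 0.0117 h
- compound 2, `CC(=O)Oc1ccccc1C(=O)O[C@H]1CO[C@H]2[C@@H]1OC[C@H]2OC(=O)c1ccc(C#N)cc1`: 0.068 h
- compound 3, `CC(=O)Oc1ccccc1C(=O)O[C@H]1CO[C@H]2[C@@H]1OC[C@H]2OC(=O)c1cccnc1`: 0.00617 h

All three share one core and an acetylsalicyloyl ester; they differ only in the second acyl group. In an ADME assay on a cell-free system (plasma, Homo sapiens) for metabolic stability, with Plasma (Rattus norvegicus) as the target, read by HPLC, at pH 7.4 (on this read-out higher numbers stand for a longer-lived compound and lower numbers for a shorter-lived compound), compound 1 stands second highest of the three numbers, with compound 3 nearest and compound 2 furthest away. The step of a 5.8-fold higher number from compound 1 to compound 2 (0.76 log units; beyond the scatter) is beyond the scatter, whereas a 1.9-fold lower number from compound 1 to compound 3 (0.28 log units; within the scatter) is within it; the step of an 11-fold lower number from compound 2 to compound 3 (1.04 log units; beyond the scatter) separates the two aryl esters clearly.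

Compound 4, `CC(=O)Oc1ccccc1C(=O)O[C@H]1CO[C@H]2[C@@H]1OC[C@H]2OC(=O)c1ccncc1`, is not yet measured. It differs from compound 1 by pyridin-4-yl in place of butyl on a carbonyl carbon. Going by the values given here, the closest precedent is the move to pyridin-3-yl, which gave only a 1.9-fold lower number from compound 1 to compound 3 (0.28 log units; within the scatter). The single aryl ester that rose, compound 2, carries a 4-cyanophenyl group, not a pyridyl, so no comparable rise is expected here. The expected change is therefore a 1.3-fold lower number from compound 1 to compound 4 (0.11 log units; within the scatter), a step not beyond the scatter, if anything slightly downward. For compound 4 the estimate in this assay is 0.009 h, with a range of 0.004 h to 0.02 h.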

Compound 4, half-life: 0.0055 h
For compound 4 the middle estimate is 1.6-fold (0.21 log units) above the measured one; the range from low to high includes it.
By their numbers in this assay, from the lowest: compounds 4, 3 and 1 (each within the scatter of the next, the first and the last beyond it); then compound 2.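

In this assay, pyridin-4-yl in place of pyridin-3-yl on the carbonyl carbon gives no readable separation, with a 1.1-fold lower number from compound 3 to compound 4 (0.05 log units; within the scatter). Against butyl, pyridin-4-yl gives a 2.1-fold lower number from compound 1 to compound 4 (0.33 log units; beyond the scatter), and against 4-cyanophenyl it gives a 12-fold lower number from compound 2 to compound 4 (1.09 log units; beyond the scatter), so of the aromatic acyl groups shown, only 4-cyanophenyl stands clear of pyridin-4-yl, and a six-membered aromatic ring at this place does not by itself go with the higher number. No evidence is available on what lies behind these differences.

Open, as far as these compounds go, is where an unsubstituted phenyl, a phenyl carrying an amine or a carboxylic acid, or a chain longer than butyl would fall relative to compound 2 and compound 4. Also open, from the compounds shown here alone, is which of the two ester groups is cleaved first.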